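The source may hold more compounds than are shown below. What is called first, only, known or untested is meant among the compounds shown, and "the series" means these compounds.

Of the compounds shown here, three have been measured in an assay on CHO cells for displacement of a labelled ligand from adenosine receptor A1 (Homo sapiens), read by scintillation counting, with a stated time of 90 min, tested at 1 uM, in the presence of a further agent that is not named here; on this read-out higher numbers stand for more inhibition at the one concentration tested (going by the name of the read-out) and lower numbers for less inhibition. Compound 1 `CCCn1c(=O)[nH]c2nc(-c3ccc(S(=O)(=O)N4CCN(c5ccc(Br)cc5)CC4)cc3)[nH]c2c1=O` gives 13%, compound 2 `CCCn1c(=O)[nH]c2nc(-c3ccc(S(=O)(=O)N4CCN(c5cccc(F)c5)CC4)cc3)[nH]c2c1=O` gives 34%, and compound 3 `CCCn1c(=O)c2[nH]c(-c3ccc(S(=O)(=O)N4CCN(c5ccc(Cl)cc5)CC4)cc3)nc2n(CC)c1=O` gives 24%. Compound 3 thus stands second highest of the three: its number sits within the scatter of compound 2, while compound 1 lies below it beyond the scatter. For the measured compounds named here, the one measured step, a number 21 percentage points higher from compound 1 to compound 2 (beyond the scatter), concerns the group on the amine nitrogen in a ring, a different place from the change now considered. Compound 4 `CCCn1c(=O)c2[nH]c(-c3ccc(S(=O)(=O)N4CCN(c5ccc(Cl)cc5)CC4)cc3)nc2n(C)c1=O` differs from compound 3 by hydrogen in place of methyl on a saturated chain carbon bound to an aromatic nitrogen. Going by the values given here, no measured step touches this place, so no shift beyond the scatter is expected; the estimated step is no change at the digits printed from compound 3 to compound 4 (within the scatter). Compound 4 is expected to give 24%, between 8% and 40%.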

Compound 4, a percentage reported as inhibition, at one concentration (the size of the read-out at that concentration, not a potency): 22%
Beside the measured number, compound 4's estimate is 2 percentage points above it; the measured number falls inside the stated range.
By their numbers in this assay, from the lowest: compounds 1, 4, 3 and 2 (each within the scatter of the next, the first and the last beyond it).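

Going from ethyl to methyl at this place gives a number 2 percentage points lower from compound 3 to compound 4 (within the scatter) in this assay. This position had not been probed by the earlier step, and here the removal of one carbon leaves no shift that can be told apart from repeat scatter. Nothing measured for these compounds bears on the reason for this result. Still open, from the compounds shown here alone, is whether a much larger group at this place, such as a butyl chain or a benzyl group, would also leave the number unmoved. A reading at one concentration also leaves open whether the potencies of compound 3 and compound 4 match.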